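Swapping Acetylphenyl for Pyridyl: An Estimate for Compound 4

A few compounds are considered here, and "the series" means these few. Any claim that something is new, unique, unknown or untested is made for them only; others in the source may bear on it.

Compound 3 `COC1Cc2c(csc2-c2ccc(C(C)=O)cc2)C2(CCN(Cc3ccccc3)CC2)O1` was tested in an assay on membranes from brain for displacement of a labelled ligand from Sigma non-opioid intracellular receptor 1 (Cavia porcellus), read by scintillation counting, with a stated time of 120 min (a higher number here means a weaker inhibitor, a lower number a stronger inhibitor), where compound 3 gives 1.6 nM. Among the three measured compounds it holds the second highest number: the unsubstituted parent compound 1 `COC1Cc2cscc2C2(CCN(Cc3ccccc3)CC2)O1` gives 0.22 nM, while compound 2 `COC1Cc2c(csc2-c2cccc3ccccc23)C2(CCN(Cc3ccccc3)CC2)O1` gives 5 nM. Compound 4 `COC1Cc2c(csc2-c2cccnc2)C2(CCN(Cc3ccccc3)CC2)O1` differs from compound 3 in one place: pyridin-3-yl in place of 4-acetylphenyl on an aromatic carbon. Among the measured compounds shown here, three measured steps bear on this change. Placing a substituent on that aromatic carbon raised the number in both cases, a 23-fold higher number from compound 1 to compound 2 (1.36 log units; beyond the scatter) and a 7.3-fold higher number from compound 1 to compound 3 (0.86 log units; beyond the scatter), whereas exchanging one substituent for another there gave only a 3.1-fold lower number from compound 2 to compound 3 (0.49 log units; beyond the scatter). Because the exchange of substituents gave a 3.1-fold lower number from compound 2 to compound 3 (0.49 log units; beyond the scatter), a further exchange at the same carbon is expected to move the number by a modest amount at most, with a lower number somewhat more likely than a higher one. The estimated step is a 1.3-fold lower number from compound 3 to compound 4 (0.12 log units; within the scatter). The estimate for compound 4 in this assay is 1.2 nM, within a range of 0.4 nM to 4 nM.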

Compound 4, inhibition constant: 2.2 nM
For compound 4 the middle estimate is 1.8-fold (0.26 log units) below the measured one; measured number inside the range.
By their numbers in this assay, from the lowest: compound 1; then compounds 3 and 4 (each within the scatter of the next); then compound 2.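

In this assay, pyridin-3-yl and 4-acetylphenyl on this aromatic carbon cannot be told apart, with a 1.4-fold higher number from compound 3 to compound 4 (0.14 log units; within the scatter), so a ring with a hetero atom and a carbon-only ring bearing an acetyl group serve here alike. The third substituent at this carbon also stays well separated from hydrogen, with a 10-fold higher number from compound 1 to compound 4 (1.00 log units; beyond the scatter), and so all three substituents shown give a higher number than the unsubstituted compound, while naphthalen-1-yl remains apart from pyridin-3-yl, with a 2.3-fold lower number from compound 2 to compound 4 (0.36 log units; beyond the scatter). No measurement shown accounts for these differences.

The compounds shown leave open whether methyl on this carbon would give a number nearer to that of compound 1. They also leave open how pyridin-4-yl, or an amine or carboxylic acid on the attached ring, would compare with pyridin-3-yl.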